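Changing the Ester Side Chain: From Compound 3 to Compound 4

The source may report more compounds than this note shows. Statements on the series, on what has been measured and on what is new or still open speak of the compounds shown alone.

Compound 1, `CC[C@H](C)[C@@H](NC(=O)Cn1cc(C2=C(c3c[nH]c4ccccc34)C(=O)N(C)C2=O)c2ccccc21)C(=O)OC`, gives > 100000 nM in a functional assay on MCF7 cells (Homo sapiens) for cytotoxicity, read by MTT assay, with a stated time of 24 h (on this read-out higher numbers stand for weaker inhibition and lower numbers for stronger inhibition), a limit of the assay rather than a number.
Compound 2, `COC(=O)[C@H](NC(=O)Cn1cc(C2=C(c3c[nH]c4ccccc34)C(=O)N(C)C2=O)c2ccccc21)[C@@H](C)O`, gives 22900 nM in this assay.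
Compound 3, `COC(=O)CCNC(=O)Cn1cc(C2=C(c3c[nH]c4ccccc34)C(=O)N(C)C2=O)c2ccccc21`, gives 47800 nM in this assay.

All three share one core and differ only in the amino acid methyl ester joined through the amide nitrogen. Compound 3 carries the simplest side chain and stands at the highest of the two numbers given; the nearest is compound 2, with a 2.1-fold higher number from compound 2 to compound 3 (0.32 log units; beyond the scatter). Compound 1 sits at the limit (the limit of > 100000 nM in this assay, at which 1 of the 3 values shown sits), so the step of an at least 2.0-fold lower number from compound 1 to compound 3 (0.32 log units; beyond the scatter) is known only as a lower bound, as is an at least 4.3-fold lower number from compound 1 to compound 2 (0.64 log units; beyond the scatter).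

Compound 4, `COC(=O)[C@H](NC(=O)Cn1cc(C2=C(c3c[nH]c4ccccc34)C(=O)N(C)C2=O)c2ccccc21)C(C)C`, has not yet been tested in this assay. The change from compound 3 is 1-(methoxycarbonyl)-2-methylpropyl in place of 2-(methoxycarbonyl)ethyl on an amide-type nitrogen. This brings the side chain close to that of compound 1, which reached the limit, and away from the hydroxy-bearing chain of compound 2, which gave the lowest number. The relevant steps therefore point towards a higher number, and compound 4 is expected to show a 1.9-fold higher number from compound 3 to compound 4 (0.27 log units; within the scatter), quite possibly ending at a limit. The estimate for compound 4 is 90000 nM, within a range from 35000 nM to 250000 nM.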

Compound 4, half-maximal inhibitory concentration: 16000 nM
Compound 4: middle estimate off by 5.6-fold (0.75 log units), on the high side; the whole stated range lies above it.
By their numbers in this assay, from the lowest: compounds 4 and 2 (each within the scatter of the next); then compound 3. At a limit, above all of these: compound 1.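

Putting 1-(methoxycarbonyl)-2-methylpropyl in place of 2-(methoxycarbonyl)ethyl on the amide-type nitrogen gives a 3.0-fold lower number from compound 3 to compound 4 (0.48 log units; beyond the scatter), so in this assay a branched side chain at this position does not by itself push the number up, while isopropyl in place of 1-hydroxyethyl gives a 1.4-fold lower number from compound 2 to compound 4 (0.16 log units; within the scatter), which lies within the scatter, so the hydroxy group of compound 2 is not needed to reach a number of this size. The change of a single methyl to hydrogen on a saturated chain carbon, three bonds along the chain from an amide-type nitrogen and a carbonyl carbon, gives an at least 6.2-fold lower number from compound 1 to compound 4 (0.79 log units; beyond the scatter), so a very small edit of this side chain can separate a measured value from one that cannot be put on the scale. Compound 1 stands at a limit of the assay and not at a number, which makes that step a bound only: the limit of > 100000 nM in this assay, at which 1 of the 4 values shown sits.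

The compounds shown leave open what a free carboxylic acid in place of the methyl ester would give, and what an amine or a longer chain on the side chain would do. They also leave open how the opposite configuration at the defined stereocentre of compound 4 would read.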